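Swapping the benzamide aryl group on a flavonol amide

The source may hold more compounds than are shown below. What is called first, only, known or untested is meant among the compounds shown, and "the series" means these compounds.

Measured so far:
compound 1 `O=C(Nc1cccc(-c2oc3cc(-c4ccc(F)cc4)ccc3c(=O)c2O)c1)c1ccc(Br)cc1` gives 13500 nM in a functional assay on A549 cells (Homo sapiens) for antiproliferative activity, read by CCK-8 assay, with a stated time of 72 h; on this read-out lower numbers stand for stronger inhibition and higher numbers for weaker inhibition
compound 2 `O=C(Nc1cccc(-c2oc3cc(-c4ccc(F)cc4)ccc3c(=O)c2O)c1)c1cccc(F)c1` gives 15400 nM in this assay

Compound 2 stands at the highest of the two numbers, and its nearest neighbour is compound 1, with a 1.1-fold higher number from compound 1 to compound 2 (0.06 log units; within the scatter) between them. That step changed only the aryl group on the carbonyl carbon of the amide, and it made no difference beyond the scatter.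

Compound 3 `Cc1cc(C)cc(C(=O)Nc2cccc(-c3oc4cc(-c5ccc(F)cc5)ccc4c(=O)c3O)c2)c1` differs from compound 2 in the same place: 3,5-dimethylphenyl in place of 3-fluorophenyl on a carbonyl carbon. Among the measured compounds shown here, the only measured step that bears on this change is the one from compound 1 to compound 2, which also exchanged one aryl group for another on the same carbonyl carbon and stayed within the scatter. On that basis no step beyond the scatter is expected for compound 3 in this assay, and a 1.1-fold lower number from compound 2 to compound 3 (0.04 log units; within the scatter) is the expected change. For the measured compounds named here, compound 3 is therefore estimated at 14000 nM, within a range from 5000 nM to 40000 nM; the range is wide because only a single comparable step, a 1.1-fold higher number from compound 1 to compound 2 (0.06 log units; within the scatter), is available.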

Compound 3, half-maximal inhibitory concentration: 3740 nM
Compound 3: middle estimate off by 3.7-fold (0.57 log units), on the high side; measured number below the stated range.
By their numbers in this assay, from the lowest: compound 3; then compounds 1 and 2 (each within the scatter of the next).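

The aryl group on the carbonyl carbon of the amide can move this number beyond the scatter: in this assay the 3,5-dimethylphenyl group gives a 4.1-fold lower number from compound 2 to compound 3 (0.61 log units; beyond the scatter) and also a 3.6-fold lower number from compound 1 to compound 3 (0.56 log units; beyond the scatter), whereas the exchange between the two halogen-bearing aryl groups in compound 1 and compound 2 stayed within it. Among these three compounds, compound 3 therefore stands apart, with the lowest number, and the change involved is small on paper: 3,5-dimethylphenyl has 8 heavy atoms against 7 for 3-fluorophenyl, both are a single six-membered aromatic ring of carbon, and neither has hydrogen-bond donors, hydrogen-bond acceptors or a net charge. Nothing given here accounts for the drop in the number.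

The compounds shown leave open whether both methyl groups are needed or whether a phenyl ring with a single methyl group would give a similar number. They also leave open what an ethyl group, a methoxy group, an amine or a carboxylic acid on this ring would do, and so whether compound 3 marks a trend or a single result.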